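Allyloxy in Place of Allyl on a Shared Core

The source may report more compounds than this note shows. Statements on the series, on what has been measured and on what is new or still open speak of the compounds shown alone.

Compound 1 `CCC1CC=CC(=O)O1` and compound 2 `C=CCCC1CC=CC(=O)O1` were both tested in a functional assay on NCI-H292 cells (Homo sapiens) for cytotoxicity, read by MTT assay, with a stated time of 72 h; a higher number here means a weaker inhibitor, a lower number a stronger inhibitor. Compound 1 reaches only the limit of the assay, > 100 ug/mL. Compound 2 likewise reaches only that limit, > 100 ug/mL. The step that the two limits leave unreadable from compound 1 to compound 2 therefore cannot be read, because of the limit of > 100 ug/mL in this assay, at which 2 of the 2 values shown sit. Compound 3 `C=CCOCC1CC=CC(=O)O1` differs from compound 2 by allyloxy in place of allyl on a saturated chain carbon bound to a saturated ring carbon. Among the measured compounds shown here, no measured step speaks to this change, so nothing beyond the scatter, in either direction, is expected from it. Compound 3 is accordingly expected near 150 ug/mL, with a range of 50 ug/mL to 400 ug/mL. The step that the limit leaves unreadable from compound 2 to compound 3 is estimated to be essentially none.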

Compound 3, half-maximal inhibitory concentration: 16.6 ug/mL
Compound 3: middle estimate off by 9.0-fold (0.96 log units), on the high side; the whole stated range lies above it.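

In this assay, this position now gives a readable change: allyloxy in place of allyl on a saturated chain carbon bound to a saturated ring carbon gives an at least 6.0-fold lower number from compound 2 to compound 3 (0.77 log units; beyond the scatter). The comparison with the smallest chain shown points the same way, with an at least 6.0-fold lower number from compound 1 to compound 3 (0.77 log units; beyond the scatter). The group on this carbon can therefore move the number, and the allyloxy group carries an oxygen that allyl lacks.

Whether that oxygen, the extra heavy atom or something else accounts for the change stays open. A propoxy group or an amine at this place would help separate these possibilities.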